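This account rests on a few compounds, and the source may have more. Where it says the series, first, only, none or still open, it means among the compounds named here.

Compound 1 `CCC1(Cc2ccccc2)OS(=O)(=O)C=C1OCCCCc1ccccc1`: in an ADME assay on HEL cells (Homo sapiens) for cytotoxicity, with a stated time of 3 days (on this read-out lower numbers stand for higher toxicity in this test and higher numbers for lower toxicity in this test), compound 1 gives >= 20000 nM, a limit of the assay.
Compound 2 `CCC1(Cc2ccccc2)OS(=O)(=O)C=C1OCc1ccc(Cl)cc1`: in this assay compound 2 gives >= 50000 nM, also a limit.
Compound 3 `CCC1(Cc2ccccc2)OS(=O)(=O)C=C1OCc1ccc(Cl)c(Cl)c1`: in this assay compound 3 gives >= 20000 nM, again a limit.

Compound 3 thus stands at the limit of >= 20000 nM in this assay, at which 2 of the 3 values shown sit, while compound 2 sits at the limit of >= 50000 nM in this assay, at which 1 of the 3 values shown sits. None of the three values is a number, so a step that the two limits leave unreadable from compound 1 to compound 2, a step that the two limits leave unreadable from compound 1 to compound 3 and a step that the two limits leave unreadable from compound 2 to compound 3 all stay unreadable. Compound 4 `CCC1(Cc2ccccc2)OS(=O)(=O)C=C1OCc1cccc(Cl)c1` differs from compound 3 by hydrogen in place of chloro on an aromatic carbon. The step that bears on it most directly is a step that the two limits leave unreadable from compound 2 to compound 3, which runs the same change the other way and cannot be sized. No step beyond the scatter is therefore expected in this assay, and compound 4 is expected at 30000 nM (15000 nM to 100000 nM), most likely reported only as a limit. The expected step is a step that the limit leaves unreadable from compound 3 to compound 4.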

Compound 4, minimum cytotoxic concentration: >= 20000 nM
Compound 4: a limit, no number (the forecaster's own chance of this, stated with the estimate: 85%); the middle value is on the limit's open side.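

In this assay, going by these compounds alone, compound 4 gives >= 20000 nM, a limit, so no step from compound 1, compound 2 or compound 3 to compound 4 can be read. With only limits shown, the compounds leave open whether any of these changes shifts the minimum cytotoxic concentration at all.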